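Selenium Propargyl Chain Replaces Bromobutynyl Thioether on Quinoline Core

The compounds below may be only part of what the source reports. "The series", "measured", "known", "first", "only" and "open" are said of these compounds alone.

Compound 1 `OCC#CCSc1cnc2ccccc2c1SCC#CCBr` stands lowest of the two numbers, giving 0.6 ug/mL in a functional assay on CCRF-CEM cells (Homo sapiens) for cytotoxicity, read by sulforhodamine B assay, with a stated time of 72 h; on this read-out higher numbers stand for weaker inhibition and lower numbers for stronger inhibition. Compound 2 `COc1c(SCC#CCO)cnc2ccccc12` gives 22 ug/mL in this assay. Compound 3 `C#CC[Se]c1c(SCC#CCO)cnc2ccccc12` differs from compound 1 by a group of 4 heavy atoms (3 carbon, 1 selenium; no ring) in place of a group of 6 heavy atoms (4 carbon, 1 sulfur, 1 bromine; no ring), on an aromatic carbon. Within the data shown here, the only measured step that bears on this change, a 37-fold higher number from compound 1 to compound 2 (1.56 log units; beyond the scatter), shows that replacing the group of 6 heavy atoms with a group of 2 heavy atoms weakens inhibition strongly. Compound 3 keeps a chain carrying a triple bond, and a milder weakening is expected for compound 3, namely a 3.3-fold higher number from compound 1 to compound 3 (0.52 log units; beyond the scatter). The estimate for compound 3 is 2 ug/mL, expected between 0.5 ug/mL and 8 ug/mL.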

Compound 3, concentration for 50% inhibition: 1.9 ug/mL
Beside the measured number, compound 3's estimate is 1.1-fold (0.02 log units) above it; low and high end bracket the measured number.
By their numbers in this assay, from the lowest: compound 1; then compound 3; then compound 2.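

In this assay, the group of 4 heavy atoms with selenium and a triple bond stands far from the small oxygen-linked group, with a 12-fold lower number from compound 2 to compound 3 (1.06 log units; beyond the scatter). Bromine is therefore not required for a low number at this position, although the change still costs something, with a 3.2-fold higher number from compound 1 to compound 3 (0.50 log units; beyond the scatter). Nothing at hand explains either step.

Going by these compounds, because sulfur, bromine and chain length all change together, their separate shares stay open. So does how an amine or a longer chain on this aromatic carbon would compare.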